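The source may report more compounds than this note shows. Statements on the series, on what has been measured and on what is new or still open speak of the compounds shown alone.

Measured in a functional assay on L1210 cells (Mus musculus) for inhibition; on this read-out higher numbers stand for weaker inhibition and lower numbers for stronger inhibition:
- compound 1 `C#CCN(Cc1ccc2nc(C)nc(O)c2c1)c1cccc(CO)c1`: 48000 nM
- compound 2 `C#CCN(Cc1ccc2nc(C)nc(O)c2c1)c1cccc(I)c1`: > 5300 nM, a limit
- compound 3 `C#CCN(Cc1ccc2nc(C)nc(O)c2c1)c1ccc(Cl)cc1`: > 4000 nM, a limit

Compound 3 stands on a limit only, > 4000 nM, and not on a number. Compound 2 also has only a limit, > 5300 nM. Among the compounds with values here, compound 1 is the only one with a number.

Compound 4 `C#CCN(Cc1ccc2nc(C)nc(O)c2c1)c1ccc(S(=O)(=O)C(F)(F)F)cc1` differs from compound 3 in one place: (trifluoromethyl)sulfonyl in place of chloro on an aromatic carbon. Within the data shown here, two measured steps bear on this part of the molecule, a step that the limit leaves unreadable from compound 1 to compound 3 and a step that the two limits leave unreadable from compound 2 to compound 3. Neither has a readable size, and neither brings in the (trifluoromethyl)sulfonyl group, so they set no size or direction for the new step.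

Among the measured compounds shown here, the one number, compound 1 at 48000 nM, suggests that weak inhibition should be expected for compound 4 as well. The expected step is a step that the limit leaves unreadable from compound 3 to compound 4, and it is only an estimate. In this assay, compound 4 is expected at 20000 nM, with an estimated range from 4000 nM to 80000 nM.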

Compound 4, half-maximal inhibitory concentration: 2750 nM
Beside the measured number, compound 4's estimate is 7.3-fold (0.86 log units) above it; measured number below the stated range.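

Compound 3, with chloro on this aromatic carbon para to a large group, stands in this assay on a limit only, > 4000 nM. Within the data shown here, with (trifluoromethyl)sulfonyl at the same place, this position gives a readable number for the first time, and the change reads as an at least 1.4-fold lower number from compound 3 to compound 4 (0.16 log units; that floor lies within the scatter). The true step could be larger than that floor, but the compounds show that this replacement of chloro does not leave inhibition out of measurable range, while the size of the gain remains unsettled.

The steps among compound 1, compound 2 and compound 3 cannot be read, and they give no measure of how this position compares with the others. Also open, from the compounds shown here alone, is how a nitrile, a carboxylic acid or an amine at this aromatic carbon would compare with (trifluoromethyl)sulfonyl.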